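Tetrazolylphenyl in Place of Chloro-Trifluoromethylphenyl on a Shared Core

A few compounds are considered here, and "the series" means these few. Any claim that something is new, unique, unknown or untested is made for them only; others in the source may bear on it.

Compound 1, `CCCS(=O)(=O)Nc1ccc(F)c(C(=O)c2n[nH]c3ncc(-c4ccccc4OC)cc23)c1F`, gives 1.9% in an assay for binding affinity to dual specificity mitogen-activated protein kinase kinase 4 (Homo sapiens), read by KINOMEscan, tested at 100 nM; on this read-out lower numbers stand for a stronger effect and higher numbers for a weaker effect at the one concentration tested.
Compound 2, `CCCS(=O)(=O)Nc1ccc(F)c(C(=O)c2n[nH]c3ncc(-c4ccc(OC)cc4)cc23)c1F`, gives 4.2% in this assay.
Compound 3, `CCCS(=O)(=O)Nc1ccc(F)c(C(=O)c2n[nH]c3ncc(-c4ccc(Cl)c(C(F)(F)F)c4)cc23)c1F`, gives 15% in this assay.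

Among the three measured compounds, compound 3 stands at the highest number, and both of its steps to the others lie beyond the scatter: a number 13.1 percentage points higher from compound 1 to compound 3 (beyond the scatter) and a number 10.8 percentage points higher from compound 2 to compound 3 (beyond the scatter). The two methoxyphenyl compounds differ from each other only within the scatter, a number 2.3 percentage points higher from compound 1 to compound 2 (within the scatter).

Compound 4, `CCCS(=O)(=O)Nc1ccc(F)c(C(=O)c2n[nH]c3ncc(-c4ccc(-c5nnn[nH]5)cc4)cc23)c1F`, is not yet measured. It differs from compound 3 in one place: 4-(1H-tetrazol-5-yl)phenyl in place of 4-chloro-3-(trifluoromethyl)phenyl on an aromatic carbon. Within the data shown here, the steps that bear on this change are those that replaced a methoxyphenyl by 4-chloro-3-(trifluoromethyl)phenyl, each of which raised the number modestly. Among the measured compounds shown here, since compound 4 removes that group again, a return toward the lower numbers of compound 1 and compound 2 is expected, though no measured compound carries a tetrazolyl group, so the size is uncertain. The step expected is a number 8 percentage points lower from compound 3 to compound 4 (within the scatter), downward in this assay. For compound 4 the estimate is 7%, with a range from 1.5% to 25%.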

Compound 4, a percentage reported as activity, at one concentration (the size of the read-out at that concentration, not a potency): 0.15%
Compound 4: the middle estimate sits 6.9 percentage points above what was measured, and the stated range ends above it.
By their numbers in this assay, from the lowest: compounds 4, 1 and 2 (each within the scatter of the next); then compound 3.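

At this position on the shared core, 4-(1H-tetrazol-5-yl)phenyl in place of 4-chloro-3-(trifluoromethyl)phenyl gives a number 14.9 percentage points lower from compound 3 to compound 4 (beyond the scatter) in this assay, so a change of this group can undo the rise seen with the chloro-trifluoromethyl compound. Replacing a methoxy group with 1H-tetrazol-5-yl gives a number 4.1 percentage points lower from compound 2 to compound 4 (within the scatter), and replacing the whole 2-methoxyphenyl group gives a number 1.8 percentage points lower from compound 1 to compound 4 (within the scatter), so this read-out does not separate the tetrazolyl compound from either methoxyphenyl compound. The position therefore holds a phenyl group bearing a five-membered aromatic ring with 4 hetero atoms without any rise beyond the scatter, and among the four compounds only compound 3 stands apart.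

Nothing shown here accounts for these numbers. From the compounds shown here alone, it remains open whether a carboxylic acid or an amine in the place of the tetrazolyl ring on the same phenyl group would stay level with compounds 1, 2 and 4, and whether these three compounds, which a single concentration does not separate, would show a stronger or weaker effect than one another at other concentrations.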